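Replacing a Cyclohexyl Group with Fluorine: Expected Cell Tolerance

The source may hold more compounds than are shown below. What is called first, only, known or untested is meant among the compounds shown, and "the series" means these compounds.

Three compounds share a common core and differ only in the group at one end. Compound 1 `FC(F)(F)c1cccc(NC(=S)Nc2cccc(Br)c2)c1` gives 14000 nM in an ADME assay on Vero 76 cells (Chlorocebus sabaeus) for cytotoxicity, read by crystal violet staining, with a stated time of 96 h; a higher number here means that more compound is tolerated, a lower number that less compound is tolerated. Compound 2 `FC(F)(F)c1cccc(NC(=S)Nc2ccc(Cl)cc2)c1` carries 4-chlorophenyl in place of 3-bromophenyl on an amide-type nitrogen and gives 11000 nM; a 1.3-fold lower number from compound 1 to compound 2 (0.10 log units; within the scatter). Compound 3 `CC[C@H]1CC[C@H](c2ccc(NC(=S)Nc3cccc(C(F)(F)F)c3)cc2)CC1` gives 10000 nM, and a 1.1-fold lower number from compound 2 to compound 3 (0.04 log units; within the scatter). Compound 3 thus sits alongside compound 1 and compound 2, with no gap to either that exceeds the scatter, so the three cannot be told apart on these numbers.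

Compound 4 `Fc1ccc(NC(=S)Nc2cccc(C(F)(F)F)c2)cc1` is the next variation: fluoro in place of 4-ethylcyclohexyl on an aromatic carbon. Two measured steps speak to this change. The step that brought in 4-ethylcyclohexyl in place of chloro at that same aromatic carbon, from compound 2 to compound 3, stayed within the scatter, and the exchange of one halogen-bearing group for another, from compound 1 to compound 2, did likewise. Since neither adding the large group nor swapping halogens shifted the number beyond the scatter, taking the group away and putting fluoro in its place is expected to leave the number essentially unchanged, the expected step being a 1.1-fold higher number from compound 3 to compound 4 (0.04 log units; within the scatter). Compound 4 is therefore estimated at about 11000 nM, with a range from 5000 nM to 25000 nM.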

Compound 4, half-maximal cytotoxic concentration: 40000 nM
Estimate against measurement, compound 4: 3.6-fold (0.56 log units) below, outside the stated range (above it).
By their numbers in this assay, from the lowest: compounds 3, 2 and 1 (each within the scatter of the next); then compound 4.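

In this assay, fluoro sets compound 4 apart from all three earlier compounds: there is a 4.0-fold higher number from compound 3 to compound 4 (0.60 log units; beyond the scatter) with fluoro in place of 4-ethylcyclohexyl, a 3.6-fold higher number from compound 2 to compound 4 (0.56 log units; beyond the scatter) with fluoro in place of chloro on the same aromatic carbon, and a 2.9-fold higher number from compound 1 to compound 4 (0.46 log units; beyond the scatter) with a fluorine-bearing group in place of a bromine-bearing one. The earlier compounds shown here made this position look indifferent, since chloro and 4-ethylcyclohexyl stayed within the scatter of each other, yet exchanging one halogen for another here moves the number beyond the scatter, so the group at this carbon can matter and the number does not simply follow the size of that group. No measurement is available to explain why fluoro stands apart here.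

The compounds shown leave open how a methoxy group, an amine or a plain hydrogen on this aromatic carbon would compare, and so whether fluoro is a lone exception or part of a wider trend. Every compound here also carries trifluoromethyl on the shared core, so whether the higher number would persist with a nitrile in its place is open too.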